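A few compounds are considered here, and "the series" means these few. Any claim that something is new, unique, unknown or untested is made for them only; others in the source may bear on it.

Compound 1 `COc1cc2cc(Oc3ccc(NC(=O)Nc4cccc(C(F)(F)F)c4)cc3)c(C)nc2cc1OC`: 9700 nM
Compound 2 `COc1cc2cc(Oc3ccc(NC(=O)Nc4ccc(Cl)c(C(F)(F)F)c4)cc3)c(C)nc2cc1OC`: 6100 nM

For the measured compounds named here, of the two compounds measured in a functional assay on OVCAR-4 cells (Homo sapiens) for inhibition, read by sulforhodamine B assay, with a stated time of 48 h (on this read-out lower numbers stand for stronger inhibition of growth and higher numbers for weaker inhibition of growth), compound 2 shows the lower number, with compound 1 as its only neighbour; the step of a 1.6-fold lower number from compound 1 to compound 2 (0.20 log units; within the scatter) lies within the scatter, so neither compound can be called stronger than the other. Compound 3 `COc1cc2cc(Oc3ccc(NC(=O)Nc4ccc(Cl)c(Cl)c4)cc3)c(C)nc2cc1OC` differs from compound 2 by chloro in place of trifluoromethyl on an aromatic carbon. Going by the values given here, no measured step swaps trifluoromethyl for chloro, so the single recorded step gives no direct guidance on this change. Compound 3 is therefore expected to stay close, an estimated step of a 1.1-fold higher number from compound 2 to compound 3 (0.06 log units; within the scatter) not beyond the scatter. The estimated value for compound 3 is 7000 nM, within 3000 nM to 16000 nM.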

Compound 3, concentration for total growth inhibition: 8300 nM
Estimate against measurement, compound 3: 1.2-fold (0.07 log units) below; low and high end bracket the measured number.
By their numbers in this assay, from the lowest: compounds 2, 3 and 1 (each within the scatter of the next).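

In this assay, chloro can take the place of trifluoromethyl on this aromatic carbon without a change beyond the scatter, with a 1.4-fold higher number from compound 2 to compound 3 (0.13 log units; within the scatter). Replacing 3-(trifluoromethyl)phenyl with 3,4-dichlorophenyl on the amide-type nitrogen gives the same kind of result, with a 1.2-fold lower number from compound 1 to compound 3 (0.07 log units; within the scatter), so the three compounds cannot be told apart and this position accepts either group here. No supporting data are available to explain this result. From the compounds shown here alone, it remains open whether a different kind of group at this position, such as an amine or a carboxylic acid, would shift the number beyond the scatter.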